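This account rests on a few compounds, and the source may have more. Where it says the series, first, only, none or still open, it means among the compounds named here.

Measured compounds in a functional assay (Cavia porcellus) with sulfonylurea receptors; K-ATP channels (Homo sapiens) as the target; a higher number here means a weaker inhibitor, a lower number a stronger inhibitor:

Compound 1 `CC(O)(C(=O)Nc1ccc(S(=O)(=O)c2ccccc2O)cc1)C(F)(F)F` — compound 1 gives 3090 nM
Compound 2 `COc1cccc(S(=O)(=O)c2ccc(NC(=O)C(C)(O)C(F)(F)F)cc2)c1` — compound 2 gives 16000 nM
Compound 3 `CC(O)(C(=O)Nc1ccc(S(=O)(=O)c2cccc(Cl)c2)cc1)C(F)(F)F` — compound 3 gives 10000 nM

Compound 3 sits among the weaker pair of this small set: it lies close to compound 2, with a 1.6-fold lower number from compound 2 to compound 3 (0.20 log units; within the scatter), and clearly apart from compound 1, with a 3.2-fold higher number from compound 1 to compound 3 (0.51 log units; beyond the scatter). All three share one core and differ only in the phenyl ring on the sulfonyl sulfur.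

Compound 4 `CC(O)(C(=O)Nc1ccc(S(=O)(=O)c2ccc([N+](=O)[O-])cc2)cc1)C(F)(F)F` continues along that same ring: 4-nitrophenyl in place of 3-chlorophenyl on a sulfonyl sulfur. Among the measured compounds shown here, the steps that bear on this position are a 5.2-fold higher number from compound 1 to compound 2 (0.71 log units; beyond the scatter) and a 3.2-fold higher number from compound 1 to compound 3 (0.51 log units; beyond the scatter), both modest weakenings when 2-hydroxyphenyl was replaced, and a 1.6-fold lower number from compound 2 to compound 3 (0.20 log units; within the scatter), which shows that swapping one substituent for another on that ring made no difference beyond the scatter. For the measured compounds named here, no measured pair involves a nitro group, so the new substituent itself is untested. On this basis compound 4 is expected to land near compound 3, with an estimated 1.1-fold higher number from compound 3 to compound 4 (0.04 log units; within the scatter) that may well stay within the scatter. The estimate for compound 4 is 11000 nM, ranging from 3500 nM to 35000 nM.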

Compound 4, half-maximal inhibitory concentration: > 30000 nM
Compound 4: no number, only a limit; the forecaster's own chance of this, stated with the estimate: 15%; middle value at least 2.7-fold (0.43 log units) from the limit.
By their numbers in this assay, from the lowest: compound 1; then compounds 3 and 2 (each within the scatter of the next). At a limit, above all of these: compound 4.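

In this assay, compound 4 has no number, only a limit: the limit of > 30000 nM in this assay, at which 1 of the 4 values shown sits.

The earlier compounds shown here showed that chloro in place of methoxy on this ring made no difference beyond the scatter, so the ring could have seemed tolerant of such swaps, but 4-nitrophenyl gives an at least 3.0-fold higher number from compound 3 to compound 4 (0.47 log units; beyond the scatter) and an at least 9.7-fold higher number from compound 1 to compound 4 (0.98 log units; beyond the scatter). Against the third compound the result is less clear, with an at least 1.8-fold higher number from compound 2 to compound 4 (0.27 log units; that floor lies within the scatter), so the limit alone does not separate compound 4 from compound 2.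

This change alters both the substituent and its place on the ring, and the compounds shown cannot tell which of the two matters. From the compounds shown here alone, it also remains open how this ring would respond to an amine or a carboxylic acid, and how far compound 4 really lies beyond its limit.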